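This account rests on a few compounds, and the source may have more. Where it says the series, first, only, none or still open, it means among the compounds named here.

Compound 1 `O=C(Nc1ccc(Cl)cc1F)c1cc(Cl)ccc1O`: 2120 nM
Compound 2 `O=C(Nc1ccc(Br)cc1F)c1cc(F)ccc1O`: 1860 nM

In a functional assay on RAW264.7 cells (Mus musculus) for inhibition, read by microscopy, with a stated time of 4 days, in the presence of a further agent that is not named here (a lower number here means a stronger inhibitor, a higher number a weaker inhibitor), compound 2 gives 1860 nM and compound 1 gives 2120 nM, two values within the scatter of each other. Compound 3 `O=C(Nc1ccc(Br)cc1F)c1cc(Cl)ccc1O` has chloro in place of fluoro on an aromatic carbon of compound 2, para to a hydroxy group: chloro in place of fluoro on an aromatic carbon. No measured step isolates this change, so its size is not shown directly. No change beyond the scatter is expected, in either direction. The expected change is a 1.0-fold higher number from compound 2 to compound 3 (0.02 log units; within the scatter). Compound 3 is estimated at 1950 nM, with an expected range of 950 nM to 4000 nM.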

Compound 3, half-maximal inhibitory concentration: 2140 nM
Compound 3: the middle estimate sits 1.1-fold (0.04 log units) below what was measured; measured number inside the range.
By their numbers in this assay, from the lowest: compounds 2, 1 and 3 (each within the scatter of the next).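

In this assay chloro in place of fluoro on an aromatic carbon, para to a hydroxy group, now has a measured step: a 1.2-fold higher number from compound 2 to compound 3 (0.06 log units; within the scatter) and so within the scatter. Bromo in place of chloro on an aromatic carbon also has its first measured step, a 1.0-fold higher number from compound 1 to compound 3 (0.00 log units; within the scatter) and likewise within the scatter, so neither halogen exchange separates these compounds. No measurement here offers an explanation for these results.
Whether an amine or a carboxylic acid para to the hydroxy group would shift the number remains open, since only halogens at that position are shown.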